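From bromo to cyano at the assay limit

The source may hold more compounds than are shown below. What is called first, only, known or untested is meant among the compounds shown, and "the series" means these compounds.

Values in an ADME assay on MCF-10A cells (Homo sapiens) for inhibition, with a stated time of 48 h (a higher number here means a weaker inhibitor, a lower number a stronger inhibitor), are as follows.
Compound 1 `O=C(Nc1ccc(Cl)cc1)N1CCC[C@H]1c1nc(-c2ccccc2)no1` gives > 50000 nM as a limit.
Compound 2 `O=C(Nc1ccc(Cl)cc1)N1CCC[C@H]1c1nc(-c2cccc(O)c2)no1` gives > 50000 nM as a limit.
Compound 3 `O=C(Nc1ccc(Cl)cc1)N1CCC[C@H]1c1nc(-c2ccc(Br)cc2)no1` gives > 50000 nM as a limit.

Compound 3 has no number of its own and stands with the other two compounds at the limit of > 50000 nM in this assay, at which 3 of the 3 values shown sit, in this assay. Compound 4 `N#Cc1ccc(-c2noc([C@@H]3CCCN3C(=O)Nc3ccc(Cl)cc3)n2)cc1` carries cyano in place of bromo on an aromatic carbon, para to a large group (cyano in place of bromo on an aromatic carbon). The same difference, cut one bond further out, reads 4-bromophenyl to 4-cyanophenyl.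

The measured steps closest to this change are a step that the two limits leave unreadable from compound 1 to compound 3 and a step that the two limits leave unreadable from compound 2 to compound 3 and neither gives a size to carry over. The same holds for the remaining step (a step that the two limits leave unreadable from compound 1 to compound 2). No step beyond the scatter is therefore expected, and the expected step is a step that the limit leaves unreadable from compound 3 to compound 4 in this reading.

For compound 4 the estimated value is 60000 nM with an expected range from 25000 nM to 120000 nM and a limit is the likelier expected outcome.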

Compound 4, half-maximal inhibitory concentration: > 50000 nM
Compound 4: only a limit was reported; the forecaster's own chance of this, stated with the estimate: 85%; the middle value does not contradict the limit.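

In this assay compound 4 gives > 50000 nM, a limit and not a number, so no step from compound 1, compound 2 or compound 3 to compound 4 can be read: the limit of > 50000 nM in this assay, at which 4 of the 4 values shown sit.

The compounds shown leave open how far these four compounds lie apart, and which change to the shared core would give a readable value in this assay.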